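Sulfur in place of oxygen in the five-membered ring

This account rests on a few compounds, and the source may have more. Where it says the series, first, only, none or still open, it means among the compounds named here.

Working notes on the series. Compound 1 `O=S(=O)(/C=C/S(=O)(=O)c1ccc(Cl)cc1)CC1=NCCO1` gives 85.5% in a functional assay for inhibition, tested at 100 uM; on this read-out lower numbers stand for less inhibition and higher numbers for more inhibition at the one concentration tested (going by the name of the read-out). Compound 2 `Cc1ccc(S(=O)(=O)/C=C/S(=O)(=O)CC2=NCCO2)cc1` gives 74.2%, and compound 3 `O=S(=O)(/C=C/S(=O)(=O)c1ccccc1)CC1=NCCO1` gives 82.1%. Every measured step sits on an aromatic carbon: a number 11.3 percentage points lower from compound 1 to compound 2 (beyond the scatter); a number 3.4 percentage points lower from compound 1 to compound 3 (within the scatter); a number 7.9 percentage points higher from compound 2 to compound 3 (within the scatter). Compound 3 therefore stands second highest of the three numbers, with compound 1 nearest and compound 2 furthest, both within the scatter.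

Compound 4 `O=S(=O)(/C=C/S(=O)(=O)c1ccccc1)CC1=NCCS1` differs from compound 3 in one place: a group of 5 heavy atoms (3 carbon, 1 nitrogen, 1 sulfur; one five-membered non-aromatic ring with 2 hetero atoms) in place of a group of 5 heavy atoms (3 carbon, 1 nitrogen, 1 oxygen; one five-membered non-aromatic ring with 2 hetero atoms), on a saturated chain carbon bound to a sulfonyl sulfur. None of the three measured steps touches this ring, and none of them exceeds modest size. Nothing measured here bears directly on the change, so no step beyond the scatter is expected in this assay. The step expected from this swap is a number 2.1 percentage points lower from compound 3 to compound 4 (within the scatter). For compound 4 the estimate is 80%, with a range from 65% to 92%.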

Compound 4, a percentage reported as inhibition, at one concentration (the size of the read-out at that concentration, not a potency): 30.4%
For compound 4 the middle estimate is 49.6 percentage points above the measured one; measured number outside the range, below it.
By their numbers in this assay, from the lowest: compound 4; then compounds 2, 3 and 1 (each within the scatter of the next, the first and the last beyond it).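

In this assay, this ring exchange gives a number 51.7 percentage points lower from compound 3 to compound 4 (beyond the scatter), a far larger step than the largest one on the aromatic carbon, a number 11.3 percentage points lower from compound 1 to compound 2 (beyond the scatter). The number at this place, on a saturated chain carbon bound to a sulfonyl sulfur, therefore responds strongly to sulfur in place of oxygen in the five-membered ring, even though the counts of heavy atoms, hydrogen-bond donors and hydrogen-bond acceptors are the same in both groups. Nothing available on these compounds accounts for the size of this step.

The compounds shown leave open whether the sulfur ring would give a similarly low number with chloro or methyl on the aromatic carbon. Going by these compounds, it is also open whether an amine or a carboxylic acid on the same chain carbon would stand nearer compound 3 or compound 4.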